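An Ethynyl Carbonyl Variant of Compound 1

The source may hold more compounds than are shown below. What is called first, only, known or untested is meant among the compounds shown, and "the series" means these compounds.

Measured so far:
compound 1 `CCC/C=C/C(=O)N(Cc1ccc(OC)c(O)c1)c1cc(OC)c(OC)c(OC)c1` gives 57 nM in a functional assay on KYSE-450 cells (Homo sapiens) for inhibition, read by MTT assay, with a stated time of 48 h; a lower number here means a stronger inhibitor, a higher number a weaker inhibitor
compound 2 `COc1ccc(CN(C(=O)C2CC2)c2cc(OC)c(OC)c(OC)c2)cc1O` gives 80 nM in this assay
compound 3 `C/C=C/C(=O)N(Cc1ccc(OC)c(C)c1)c1cc(OC)c(OC)c(OC)c1` gives 32900 nM in this assay

Compound 1 has the lowest number of the three. Compound 2 sits close to it, within the scatter, while compound 3 lies far above it, beyond the scatter. Among the compounds with values here, compound 3 differs from compound 1 in two places, so its values show only that the pair together moves the number sharply; nothing can be assigned to either change alone.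

Compound 4 `C#CC(=O)N(Cc1ccc(OC)c(O)c1)c1cc(OC)c(OC)c(OC)c1` is the next variant. Its difference from compound 1 is ethynyl in place of pent-1-en-1-yl on a carbonyl carbon. Within the data shown here, the one measured step that bears on this site is a 1.4-fold higher number from compound 1 to compound 2 (0.15 log units; within the scatter), where the same pent-1-en-1-yl group on the same carbonyl carbon gave way to cyclopropyl and the number stayed within the scatter. A second small group entering at that carbonyl carbon is therefore expected to behave alike, with no step beyond the scatter in this assay, that is a 1.1-fold higher number from compound 1 to compound 4 (0.06 log units; within the scatter). Compound 4 is estimated at 65 nM, in the range 20 nM to 220 nM.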

Compound 4, half-maximal inhibitory concentration: 570 nM
Compound 4: the middle estimate sits 8.8-fold (0.94 log units) below what was measured, outside the stated range (above it).
By their numbers in this assay, from the lowest: compounds 1 and 2 (each within the scatter of the next); then compound 4; then compound 3.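

The carbonyl carbon of compound 1 does not treat every replacement for pent-1-en-1-yl alike in this assay. Ethynyl gives a 10-fold higher number from compound 1 to compound 4 (1.00 log units; beyond the scatter), and the same group set against cyclopropyl gives a 7.1-fold higher number from compound 2 to compound 4 (0.85 log units; beyond the scatter), so both steps lie beyond the scatter, whereas the step to cyclopropyl alone stayed within it; the number at this site therefore depends on which group enters, and not only on the loss of pent-1-en-1-yl. Nothing available explains why ethynyl parts from the other two groups.

The compounds shown leave open how a saturated chain such as propyl, or a phenyl group or an amine, would read on the same carbonyl carbon in this assay. The two changes that separate compound 3 from compound 1 also remain unresolved, as neither appears alone.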